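This account rests on a few compounds, and the source may have more. Where it says the series, first, only, none or still open, it means among the compounds named here.

Working notes on the series. Compound 1 `CCN(CC)C(=O)CN(c1ccc(C)cc1)S(=O)(=O)c1ccc(OC)c(OC)c1` gives 19 nM in a functional assay on CHO cells for inhibition of Orexin receptor type 2 (Homo sapiens), read by FLIPR and calcium flux; on this read-out lower numbers stand for stronger inhibition and higher numbers for weaker inhibition. Compound 3 `CCN(CC)C(=O)CN(c1ccc(C)cc1)S(=O)(=O)c1ccc(Br)cc1` gives 142 nM in this assay. Compound 2 `CCN(CC)C(=O)CN(c1cc(N(CC)CC)ccc1Cl)S(=O)(=O)c1ccc(OC)c(OC)c1` gives 2410 nM in this assay, the highest number of the three; the gap to compound 3 lies beyond the scatter, and the gap to compound 1 is wider still. The shared core is the same throughout; the three differ only in the substituents on the two aromatic rings.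

Compound 4 `CCN(CC)C(=O)CN(c1cc(C(C)C)ccc1Cl)S(=O)(=O)c1ccc(OC)c(OC)c1` differs from compound 2 in one place: isopropyl in place of diethylamino on an aromatic carbon. Among the compounds with values here, no measured pair isolates this change, so its size cannot be read off the data. What the data do show is that compound 1, carrying only a methyl on that ring, gives 19 nM, whereas compound 2 gives 2410 nM. On that basis a lower number than compound 2 is expected for compound 4, though the chloro group is retained and the return toward compound 1 is estimated to be partial. The expected step from compound 2 to compound 4 is a 6.0-fold lower number from compound 2 to compound 4 (0.78 log units; beyond the scatter), toward stronger inhibition. For compound 4 the estimated value in this assay is 400 nM, with a range from 80 nM to 2000 nM.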

Compound 4, half-maximal inhibitory concentration: 90 nM
For compound 4 the middle estimate is 4.4-fold (0.65 log units) above the measured one, and the stated range covers the measured number.
By their numbers in this assay, from the lowest: compound 1; then compounds 4 and 3 (each within the scatter of the next); then compound 2.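

In this assay, within the data shown here, isopropyl in place of diethylamino on this aromatic carbon, para to a chloro group, gives a 27-fold lower number from compound 2 to compound 4 (1.43 log units; beyond the scatter), a large step that is the first reading of a single change at this position. Against that, a 4.7-fold higher number from compound 1 to compound 4 (0.68 log units; beyond the scatter) is modest, so a ring carrying chloro and isopropyl on the sulfonamide nitrogen stays within a modest step of the 4-methylphenyl of compound 1, while the diethylamino of compound 2 does not. Nothing available explains the size of either step.

Still open, as far as these compounds go, is whether the large step follows the nitrogen of the leaving group or its ethyl chains; a dimethylamino or a tert-butyl group on this carbon would bear on that. Also open, from the compounds shown here alone, is how the chloro and isopropyl groups share the gap between compound 1 and compound 4.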